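Series notes: a heteroaryl group in place of 2-methylphenyl

A few compounds are considered here, and "the series" means these few. Any claim that something is new, unique, unknown or untested is made for them only; others in the source may bear on it.

Three compounds of the shared core have been run in a functional assay on BJAB cells (Homo sapiens) for antiproliferative activity, with a stated time of 4 days; a lower number here means that less compound is needed, a higher number that more compound is needed for the effect. Compound 1 `Cc1ccccc1-c1c(C)nn(-c2nc(-c3ccc(Cl)c(Cl)c3)c(SC(C)C)s2)c1C(=O)O` gives 5500 nM, the higher of the two numbers in hand. Compound 2 `Cc1c(-c2cc(Cl)cc(Cl)c2)c(C(=O)O)nn1-c1nc(-c2cc(Cl)cc(Cl)c2)c(SC(C)C)s1` gives 2000 nM, and the gap between compound 1 and compound 2 lies beyond the usual scatter. Compound 3 `Cc1c(-c2cc(Cl)cc(Cl)c2)c(C(=O)O)nn1-c1nc(-c2ccncc2)c(SC(C)C)s1` is recorded as "not active" (no number reported), with no number attached. Going by the values given here, no pair of measured compounds differs in a single place, so no single-point step has been measured.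

Compound 4 `Cc1nn(-c2nc(-c3ccc(Cl)c(Cl)c3)c(SC(C)C)s2)c(C(=O)O)c1-c1cnn(C)c1` is the next candidate for this assay. Against compound 1 it shows one difference: 1-methyl-1H-pyrazol-4-yl in place of 2-methylphenyl on an aromatic carbon. Among the compounds with values here, no measured pair probes a change at that place, so the expectation rests on the spread of results seen so far, where one compound of the core already returns no number at all.

For compound 4 the expected result in this assay is 8000 nM, with a range from 2500 nM to 25000 nM. The estimate implies a step of a 1.5-fold higher number from compound 1 to compound 4 (0.16 log units; within the scatter), a modest move toward a higher number that may well sit within the scatter. A real chance remains that compound 4 returns no number, as compound 3 did.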

Compound 4, half-maximal effective concentration: 6800 nM
Beside the measured number, compound 4's estimate is 1.2-fold (0.07 log units) above it; low and high end bracket the measured number.
By their numbers in this assay, from the lowest: compound 2; then compounds 1 and 4 (each within the scatter of the next).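

In this assay, 1-methyl-1H-pyrazol-4-yl in place of 2-methylphenyl gives a 1.2-fold higher number from compound 1 to compound 4 (0.09 log units; within the scatter), the first single-place step read in this series, so the two compounds cannot be told apart at this aromatic carbon, which lies next to the ring atom that bears a carboxy group and next to the ring atom that bears a methyl group. At this position, the read-out therefore does not separate a six-membered aromatic ring of carbon only, with 0 hydrogen-bond acceptors, from a five-membered aromatic ring with 2 hetero atoms and 2 hydrogen-bond acceptors, at least for this one pair on the core of compound 1. No supporting measurement bears on why the two groups give matching results, and this single step gives no explanation of its own.

The compounds shown leave open how far this position accepts other kinds of group, such as an aminomethyl group, a morpholine or a longer alkyl chain in place of the aromatic ring. From the compounds shown here alone, it also remains open whether any replacement at this carbon can bring the number in this assay clearly below that of compound 1.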